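Ring Contraction on the Amide Nitrogen of Compound 3

The source may report more compounds than this note shows. Statements on the series, on what has been measured and on what is new or still open speak of the compounds shown alone.

Of the compounds shown here, three sharing one core have been measured in a physicochemical assay for solubility, read by spectrophotometry, measured as kinetic solubility, at pH 8, tested at 500 uM; on this read-out lower numbers stand for lower solubility and higher numbers for higher solubility. Compound 1 `CN1CCCC(NS(=O)(=O)c2ccccc2Nc2cc(-c3ccc4ccn(C)c4c3)c3nccnc3c2)C1` gives 9 ug/mL. Compound 2 `Cn1ccc2ccc(-c3cc(Nc4cnccc4C(=O)NCc4cncnc4)cc4nccnc34)cc21` gives 233 ug/mL, and compound 3 `CC(=O)N1CCCC(NC(=O)c2ccncc2Nc2cc(-c3ccc4ccn(C)c4c3)c3nccnc3c2)C1` gives 212 ug/mL. On these numbers compound 3 stands second highest of the three; its nearest neighbour is compound 2, within the scatter, while compound 1 is far below it, beyond the scatter. Going by the values given here, the one step between compounds that differ in a single place, a 1.1-fold lower number from compound 2 to compound 3 (0.04 log units; within the scatter), shows that swapping the group on the amide-type nitrogen left the number where it was.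

Compound 4 `CC(=O)N1CCC(NC(=O)c2ccncc2Nc2cc(-c3ccc4ccn(C)c4c3)c3nccnc3c2)C1` differs from compound 3 at that same nitrogen: 1-acetylpyrrolidin-3-yl in place of 1-acetylpiperidin-3-yl on an amide-type nitrogen. Among the compounds with values here, no measured step covers this exact change, but the only step at this position was flat, so no movement beyond the scatter is expected in this assay. Compound 4 is therefore estimated at 200 ug/mL, with a range from 100 ug/mL to 400 ug/mL, which means an expected step of a 1.1-fold lower number from compound 3 to compound 4 (0.03 log units; within the scatter).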

Compound 4, solubility: 253 ug/mL
Compound 4: middle estimate off by 1.3-fold (0.10 log units), on the low side; measured number inside the range.
By their numbers in this assay, from the lowest: compound 1; then compounds 3, 2 and 4 (each within the scatter of the next).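

Ring size on this nitrogen now has a step of its own: 1-acetylpyrrolidin-3-yl in place of 1-acetylpiperidin-3-yl gives a 1.2-fold higher number from compound 3 to compound 4 (0.08 log units; within the scatter) in this assay for this one change. Set against the (pyrimidin-5-yl)methyl group, the five-membered ring gives a 1.1-fold higher number from compound 2 to compound 4 (0.04 log units; within the scatter) on the same read-out, so compounds 2, 3 and 4 all lie within the scatter of one another despite carrying three different groups at this position. Nothing available explains why these changes leave the number in place.

Going by these compounds, what an amine in place of the acetyl group, or a carboxylic acid on the ring, would do at this nitrogen stays open. Compound 1 differs from the others in more than one place, so no single change can be tied to its lower number.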